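The source may hold more compounds than are shown below. What is called first, only, known or untested is meant among the compounds shown, and "the series" means these compounds.

For the measured compounds named here, compound 1, `O=C1NC(=S)/C(=C/c2ccccc2Cl)S1`, is one of two compounds measured in a functional assay on NCI-H292 cells (Homo sapiens) for cytotoxicity, read by MTT assay, with a stated time of 72 h, tested at 5 ug/mL (a lower number here means less inhibition of growth, a higher number more inhibition of growth at the concentration tested), where compound 1 gives 34.2%. The second compound, compound 2, `O=C1NC(=S)/C(=C/c2ccc(Cl)cc2Cl)S1`, gives in this assay a reading of 29.3%. The step between them, chloro in place of hydrogen on an aromatic carbon, amounts to a number 4.9 percentage points lower from compound 1 to compound 2 (within the scatter). On these two numbers compound 1 stands highest, with compound 2 the nearest, though the gap between them lies within the scatter, so no order between the two can be claimed.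

Compound 3, `O=C1NC(=S)/C(=C/c2c(Cl)cccc2Cl)S1`, has not yet been measured in this assay. It differs from compound 1 in that (chloro in place of hydrogen on an aromatic carbon). Going by the values given here, the only measured step that bears on this change is the one from compound 1 to compound 2, which also replaced a hydrogen with a chloro group on an aromatic carbon and stayed within the scatter at a number 4.9 percentage points lower from compound 1 to compound 2 (within the scatter). Among the compounds with values here, nothing among the measured compounds therefore points to a step beyond the scatter in either direction. Compound 3 is accordingly expected to give about 32% in this assay, in a range from 20% to 44%. This estimate corresponds to a step of a number 2.2 percentage points lower from compound 1 to compound 3 (within the scatter), which is expected to stay within the scatter.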

Compound 3, percent growth inhibition at one concentration: 10.3%
Estimate against measurement, compound 3: 21.7 percentage points above, and the stated range ends above it.
By their numbers in this assay, from the lowest: compound 3; then compounds 2 and 1 (each within the scatter of the next).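

The same kind of change, chloro in place of hydrogen on an aromatic carbon, proves not to be neutral wherever it is made: placed ortho to a group of 8 heavy atoms and meta to a chloro group, it gives in this assay a number 23.9 percentage points lower from compound 1 to compound 3 (beyond the scatter), whereas at its place in compound 2 it gave a number 4.9 percentage points lower from compound 1 to compound 2 (within the scatter). The earlier pair alone suggested that adding a chloro group to the aromatic ring of compound 1 might change little, but the outcome of this change clearly depends on where on the ring the group enters, and at this position the loss of growth inhibition is beyond the scatter. No measurement shown here accounts for why this position behaves differently from the other.

On these data alone, it remains open whether the loss belongs to chloro itself or would also follow from another group at this place, such as fluoro, methyl, methoxy or an amine. As far as these compounds go, it also remains open whether removing the chloro group already on compound 1, while keeping the new one, would restore the reading of compound 1.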